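The compounds below may be only part of what the source reports. "The series", "measured", "known", "first", "only" and "open" are said of these compounds alone.

Measured compounds:
compound 1 `CCCS(=O)(=O)Nc1ccc(F)c(C(=O)c2n[nH]c3ncc(-c4cccc(C)c4)cc23)c1F`, 15%
compound 2 `CCCS(=O)(=O)Nc1ccc(F)c(C(=O)c2n[nH]c3ncc(-c4ccccc4OC)cc23)c1F`, 1.9%
compound 3 `CCCS(=O)(=O)Nc1ccc(F)c(C(=O)c2n[nH]c3ncc(-c4ccc(OC)cc4)cc23)c1F`, 4.2%

All three were read in an assay for binding affinity to dual specificity mitogen-activated protein kinase kinase 4 (Homo sapiens), read by KINOMEscan, tested at 100 nM; a higher number here means a weaker effect of the compound at the concentration tested, a lower number a stronger effect. Compound 2 sits at the low end of the three numbers: its separation from compound 1, a number 13.1 percentage points lower from compound 1 to compound 2 (beyond the scatter), is beyond the scatter, while its separation from compound 3, a number 2.3 percentage points higher from compound 2 to compound 3 (within the scatter), is within it. The step of a number 10.8 percentage points lower from compound 1 to compound 3 (beyond the scatter) likewise puts a methoxyphenyl compound well under the methylphenyl one. Compound 4 `CCCS(=O)(=O)Nc1ccc(F)c(C(=O)c2n[nH]c3ncc(-c4ccc(OC)cc4Cl)cc23)c1F` is not yet measured. Its change from compound 2: 2-chloro-4-methoxyphenyl in place of 2-methoxyphenyl on an aromatic carbon. Among the measured compounds shown here, no measured step adds a chlorine. Compound 2 and compound 3 give numbers within scatter of each other, so a step in this assay beyond the scatter is not expected from compound 2 to compound 4; the estimated step is a number 1.6 percentage points higher from compound 2 to compound 4 (within the scatter). Compound 4 is expected to give 3.5%, within 0.5% to 14%.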

Compound 4, a percentage reported as activity, at one concentration (the size of the read-out at that concentration, not a potency): 5.3%
Beside the measured number, compound 4's estimate is 1.8 percentage points below it; the measured number falls inside the stated range.
By their numbers in this assay, from the lowest: compounds 2, 3, 4 and 1 (each within the scatter of the next, the first and the last beyond it).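

Chloro on the 4-methoxyphenyl group gives a step within the scatter in this assay (a number 1.1 percentage points higher from compound 3 to compound 4 (within the scatter)), so this position accepts the 2-chloro-4-methoxyphenyl group. The step against the 2-methoxyphenyl group also stays within the scatter (a number 3.4 percentage points higher from compound 2 to compound 4 (within the scatter)). Against the 3-methylphenyl group the step is likewise within the scatter (a number 9.7 percentage points lower from compound 1 to compound 4 (within the scatter)), unlike the steps from that group to either methoxyphenyl group. Nothing measured here offers a reason for these steps.

Open: whether an amine or a carboxylic acid on this phenyl ring would give a step beyond the scatter in this assay; a longer chain in place of methoxy is equally untested in the compounds shown.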